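Working notes: from compound 2 to compound 3

The source may report more compounds than this note shows. Statements on the series, on what has been measured and on what is new or still open speak of the compounds shown alone.

Compound 1 `COc1ccc(CN(C(=O)COc2cc(OC)c(OC)c(OC)c2)c2cc(OC)c(OC)c(OC)c2)cc1` gives > 80000 nM as a limit
Compound 2 `COc1ccc(CN(C(=O)CSc2nnnn2C)c2cc(OC)c(OC)c(OC)c2)cc1` gives 10500 nM as a number

Going by the values given here, in a functional assay on PC-3 cells (Homo sapiens) for antiproliferative activity, read by MTT assay, with a stated time of 48 h (on this read-out higher numbers stand for weaker inhibition and lower numbers for stronger inhibition), compound 2 (10500 nM) holds the only true number so far. Compound 3 `COc1ccc(CN(C(=O)CSc2nc3ccccc3o2)c2cc(OC)c(OC)c(OC)c2)cc1` carries 1,3-benzoxazol-2-yl in place of 1-methyl-1H-tetrazol-5-yl on a sulfur. Among the compounds with values here, no measured step covers this change, so the expectation starts from compound 2 (10500 nM) and no shift beyond the scatter is expected in this assay in either direction. The estimated step (a 1.3-fold lower number from compound 2 to compound 3 (0.12 log units; within the scatter)) stays small. Compound 3 is expected near 8000 nM within an estimated range of 2500 nM to 30000 nM for now.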

Compound 3, half-maximal inhibitory concentration: 3530 nM
For compound 3 the middle estimate is 2.3-fold (0.36 log units) above the measured one; measured number inside the range.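

In this assay the group on this sulfur proves able to move the number: 1,3-benzoxazol-2-yl in place of 1-methyl-1H-tetrazol-5-yl gives a 3.0-fold lower number from compound 2 to compound 3 (0.47 log units; beyond the scatter), a modest step and the first readable one in the series. Nothing measured here accounts for this step.

The compounds shown leave open whether the step follows the added six-membered aromatic ring of carbon only or the changed atoms of the five-membered ring. A 1,3-benzothiazol-2-yl group on the same sulfur, or an amine on the benzoxazole, would remain to be read.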